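The source may report more compounds than this note shows. Statements on the series, on what has been measured and on what is new or still open speak of the compounds shown alone.

Compound 1 `CCCc1nnc(SCc2ccccc2)n1N1C(=O)c2ccccc2C1=O` and compound 2 `CCCc1nnc(SCC(=O)c2ccc(Cl)cc2)n1N1C(=O)c2ccccc2C1=O` share one core and differ in a single place. In a functional assay on HepG2 cells (Homo sapiens) for cytotoxicity, read by MTT assay, with a stated time of 48 h (on this read-out lower numbers stand for stronger inhibition and higher numbers for weaker inhibition), compound 1 gives > 200000 nM, which is a limit of the assay rather than a number. In this assay compound 2 gives > 200000 nM, again only a limit. The step that the two limits leave unreadable from compound 1 to compound 2 therefore cannot be read. Compound 3 `CCCc1nnc(SCC(=O)c2ccc(C)cc2)n1N1C(=O)c2ccccc2C1=O` differs from compound 2 by methyl in place of chloro on an aromatic carbon. For the measured compounds named here, both measured values sit at the limit of > 200000 nM in this assay, at which 2 of the 2 values shown sit, so no measured step bears on this change and no direction can be drawn from the numbers. Compound 3 is expected to give 300000 nM, between 100000 nM and 1000000 nM, an expected step that the limit leaves unreadable from compound 2 to compound 3 within the scatter.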

Compound 3, half-maximal inhibitory concentration: > 200000 nM
Compound 3: only a limit was reported (the forecaster's own chance of this, stated with the estimate: 80%); the middle value lies beyond the limit too.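

Compound 3 gives no readable step against compound 1 or compound 2, as all three values are limits of the assay rather than numbers: the limit of > 200000 nM in this assay, at which 3 of the 3 values shown sit. On these data alone, whether any change to the shared core would give a measurable value in this assay stays open.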